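A few compounds are considered here, and "the series" means these few. Any claim that something is new, unique, unknown or untested is made for them only; others in the source may bear on it.

Three compounds were tested in a functional assay on the whole organism (strain Wistar Albino) for inhibition, with Rattus norvegicus as the target, read by paw edema, with a stated time of 3 h, at a dose of 20 mg/kg; on this read-out higher numbers stand for more inhibition at the one dose given (going by the name of the read-out) and lower numbers for less inhibition. Compound 1, `COc1ccc(Cl)c(-c2nnc3n2NC(c2ccc([N+](=O)[O-])o2)S3)c1`, gave 21.7% in this assay. Compound 2, `COc1ccc(Cc2nnc3n2NC(c2ccc([N+](=O)[O-])o2)S3)cc1OC`, gave 21.4%; the difference between the cores of compound 1 and compound 2 is not broken down here. Compound 3, `COc1ccc(Cl)c(-c2nnc3n2NC(c2ccc[nH]2)S3)c1`, gave 18.4%. The change from compound 1 to compound 3, (1H-pyrrol-2-yl in place of 5-nitrofuran-2-yl on a saturated ring carbon), produced a step of a number 3.3 percentage points lower from compound 1 to compound 3 (within the scatter), which lies within the usual scatter of this kind of measurement. Compound 4, `COc1ccc(Cc2nnc3n2NC(c2ccc[nH]2)S3)cc1OC`, is not yet measured; it carries the same change relative to compound 2, (1H-pyrrol-2-yl in place of 5-nitrofuran-2-yl on a saturated ring carbon), on the same place of the shared core. Among the measured compounds shown here, since the one measured example of this change, from compound 1 to compound 3, stayed within scatter, the step from compound 2 to compound 4 is expected to be about a number 2.9 percentage points lower from compound 2 to compound 4 (within the scatter). Compound 4 is therefore estimated at 18.5%, with a likely range from 10% to 27%.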

Compound 4, a percentage reported as inhibition, in the whole organism at one dose (the size of the read-out at that dose, not a potency): 17.7%
Compound 4: middle estimate off by 0.8 percentage points, on the high side; measured number inside the range.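

In this assay the swap of 5-nitrofuran-2-yl for 1H-pyrrol-2-yl on the saturated ring carbon gives a number 3.7 percentage points lower from compound 2 to compound 4 (within the scatter) and, set beside the earlier step, it looks the same on both cores: the same change on two cores in this assay, a number 3.3 percentage points lower (within the scatter) from compound 1 to compound 3 and a number 3.7 percentage points lower (within the scatter) from compound 2 to compound 4, 0.4 percentage points apart, within the scatter of two such steps. Carrying this change from one core to the other therefore gave a matching result here, and neither core showed a large step. Since both steps lie within the scatter, this does not show that the swap has any real effect, and two cores say nothing about other cores in the series.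

The compounds shown leave open what a clearly different group on that saturated ring carbon would do, such as a carboxylic acid, an amine or a longer alkyl chain. They also leave open whether any such group would move the result beyond the scatter.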